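From compound 3 to compound 4: a smaller ester group

This account rests on a few compounds, and the source may have more. Where it says the series, first, only, none or still open, it means among the compounds named here.

In an ADME assay on HepG2 2.2.15 cells (Homo sapiens) for cytotoxicity (a higher number here means that more compound is tolerated, a lower number that less compound is tolerated), compound 1 `O=C(OCCc1c(-c2ccccc2Cl)c2cc(Cl)ccc2[nH]c1=O)C1CCCCC1` gives 38000 nM and compound 2 `O=C(OCCc1c(-c2ccccc2Cl)c2cc(Cl)ccc2[nH]c1=O)c1cccnc1` gives 170000 nM as its half-maximal cytotoxic concentration. Compound 3 `O=C(/C=C/c1ccc(C(F)(F)F)cc1)OCCc1c(-c2ccccc2Cl)c2cc(Cl)ccc2[nH]c1=O` reaches only the limit > 1400000 nM of the assay, so no number is known for it. Compound 4 `C/C=C(\C)C(=O)OCCc1c(-c2ccccc2Cl)c2cc(Cl)ccc2[nH]c1=O` has 1-methylprop-1-en-1-yl in place of 2-(4-(trifluoromethyl)phenyl)ethenyl on a carbonyl carbon and is otherwise the same. Going by the values given here, two measured steps bear on this change: an at least 36-fold higher number from compound 1 to compound 3 (1.56 log units; beyond the scatter) (large) and an at least 8.2-fold higher number from compound 2 to compound 3 (0.91 log units; beyond the scatter) (at least modest) both bring in the group that compound 4 loses. A large fall is therefore expected, with an at least 11-fold lower number from compound 3 to compound 4 (1.06 log units; beyond the scatter) as the estimated step in this assay here. The estimated value for compound 4 is 120000 nM with an expected range from 30000 nM to 600000 nM for now.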

Compound 4, half-maximal cytotoxic concentration: 350000 nM
Compound 4: the middle estimate sits 2.9-fold (0.46 log units) below what was measured, within the range that was stated.
By their numbers in this assay, from the lowest: compound 1; then compound 2; then compound 4. At a limit, above all of these: compound 3.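

At this carbonyl carbon, a group with no ring also raises the number in this assay, with a 9.2-fold higher number from compound 1 to compound 4 (0.96 log units; beyond the scatter) and a 2.1-fold higher number from compound 2 to compound 4 (0.31 log units; beyond the scatter). The shorter 1-methylprop-1-en-1-yl group does not match 2-(4-(trifluoromethyl)phenyl)ethenyl, with an at least 4.0-fold lower number from compound 3 to compound 4 (0.60 log units; beyond the scatter). That step is only a bound, because compound 3 stands at a limit: the limit of > 1400000 nM in this assay, at which 1 of the 4 values shown sits.

The compounds shown leave open how a saturated butyl chain, or an amine on the ester group, would read in this assay. They also leave the true size of the step to compound 3 unknown.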